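A Larger Group on the Carbonyl of Compound 3

The source may hold more compounds than are shown below. What is called first, only, known or untested is meant among the compounds shown, and "the series" means these compounds.

Three relatives sharing one core have been measured in a functional assay on K562 cells (Homo sapiens) for cytotoxicity, read by MTT assay; on this read-out higher numbers stand for weaker inhibition and lower numbers for stronger inhibition. Compound 1 `COc1ccc(/C=C/C(=O)c2ccc(OC)c3c2OC(C)(C)C=C3)cc1OCCCN(C)C` gives 2920 nM, compound 2 `CCCCC(=O)Oc1cc(/C=C/C(=O)c2ccc(OC)c3c2OC(C)(C)C=C3)ccc1OC` gives 240 nM, and compound 3 `COc1ccc(/C=C/C(=O)c2ccc(OC)c3c2OC(C)(C)C=C3)cc1OC(=O)C(C)C` gives 570 nM, which puts compound 3 in the middle of the three. Compound 4 `COc1ccc(/C=C/C(=O)Oc2cc(/C=C/C(=O)c3ccc(OC)c4c3OC(C)(C)C=C4)ccc2OC)cc1` keeps the core and changes one group: 2-(4-methoxyphenyl)ethenyl in place of isopropyl on a carbonyl carbon. In words, this is 2-(4-methoxyphenyl)ethenyl in place of isopropyl on a carbonyl carbon.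

Among the compounds with values here, the closest precedent is a change at this same carbon, isopropyl in place of butyl, which gave a 2.4-fold higher number from compound 2 to compound 3 (0.38 log units; beyond the scatter). That modest step shows that the group on this carbon can move the number, but only two small chains have been compared, and neither contains a ring like the incoming group. Two larger steps provide broader context: a 12-fold lower number from compound 1 to compound 2 (1.09 log units; beyond the scatter) and a 5.1-fold lower number from compound 1 to compound 3 (0.71 log units; beyond the scatter). Both replace 3-(dimethylamino)propyl with a carbonyl-bearing group on the oxygen. Compound 4 also has a carbonyl group there, so it is expected to stay nearer compound 3 than compound 1.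

As far as these compounds go, the direction remains open, and the expected change is small: a 1.1-fold lower number from compound 3 to compound 4 (0.06 log units; within the scatter). For compound 4 the estimated value is 500 nM, with an expected range from 150 nM to 1700 nM.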

Compound 4, half-maximal inhibitory concentration: 380 nM
The estimate for compound 4 lay 1.3-fold (0.12 log units) above the measured number, and the stated range covers the measured number.
By their numbers in this assay, from the lowest: compounds 2, 4 and 3 (each within the scatter of the next, the first and the last beyond it); then compound 1.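

In this assay, the carbonyl carbon accepts 2-(4-methoxyphenyl)ethenyl, with its six-membered aromatic ring and its double bond, and neither comparison with the small chains can be told apart from the usual scatter (a 1.5-fold lower number from compound 3 to compound 4 (0.18 log units; within the scatter); a 1.6-fold higher number from compound 2 to compound 4 (0.20 log units; within the scatter)). Isopropyl and butyl therefore do not mark the upper size of what this place allows, and compound 4 also stands well clear of the 3-(dimethylamino)propyl compound (a 7.7-fold lower number from compound 1 to compound 4 (0.89 log units; beyond the scatter)), so all three compounds with a carbonyl group on this oxygen differ from compound 1 by more than the scatter. Nothing measured here explains why the numbers fall this way.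

The ring and the double bond enter together in compound 4, so the compounds shown cannot say what each contributes alone, and a plain phenyl or a saturated 2-(4-methoxyphenyl)ethyl on the same carbon would be needed to separate them. As far as these compounds go, how a carboxylic acid at the end of this group, or a chain longer than butyl, would read at this place also remains open.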